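A few compounds are considered here, and "the series" means these few. Any claim that something is new, unique, unknown or untested is made for them only; others in the source may bear on it.

Measured so far:
compound 1, `COc1cc(C#N)cc(OC)c1Oc1nc(Nc2ccc(C#N)cc2)nc2ccccc12`, 194000 nM
compound 2, `N#Cc1ccc(Nc2nc(Oc3ccc(Cl)cc3Cl)c3ccccc3n2)cc1`, 32000 nM

In an ADME assay on MT4 cells (Homo sapiens) for cytotoxicity, read by MTT assay, with a stated time of 4 days (on this read-out lower numbers stand for higher toxicity in this test and higher numbers for lower toxicity in this test), compound 2 gives 32000 nM, the lower of the two numbers recorded to date. Compound 1 gives 194000 nM in this assay, a higher number, and the gap between compound 1 and compound 2 is beyond the scatter, so compound 2 is the more cytotoxic of the pair as measured. Going by the values given here, the two measured compounds differ in more than one place, so no measured step isolates a single structural change in this assay.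

Compound 3, `N#Cc1ccc(Nc2nc(Oc3ccc(Br)cc3)c3ccccc3n2)cc1`, has not been measured. It differs from compound 2 in one place: 4-bromophenyl in place of 2,4-dichlorophenyl on an oxygen on an aromatic ring. Among the compounds with values here, nothing among the measured compounds shows how this change acts on cytotoxicity in this assay. The working expectation is that compound 3 stays in the region of compound 2, with the step of a 1.6-fold higher number from compound 2 to compound 3 (0.19 log units; within the scatter) expected to be small, toward a higher number, and possibly not beyond the scatter. Compound 3 is therefore estimated at 50000 nM in this assay, with a range from 15000 nM to 160000 nM.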

Compound 3, half-maximal cytotoxic concentration: 215000 nM
Compound 3: the middle estimate sits 4.3-fold (0.63 log units) below what was measured, and the stated range ends below it.
By their numbers in this assay, from the lowest: compound 2; then compounds 1 and 3 (each within the scatter of the next).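

Going by these compounds alone, on an oxygen on an aromatic ring, 4-bromophenyl in place of 2,4-dichlorophenyl gives the first single-place comparison, and in this assay it gives a 6.7-fold higher number from compound 2 to compound 3 (0.83 log units; beyond the scatter). The earlier compounds shown here differed in more than one place and could not tie any gap to one position, whereas here the aryl group on this oxygen is the only difference, and changing it moves the number toward lower toxicity in this test by more than the scatter, so this position is not silent for cytotoxicity. No measurement shown here accounts for the size or direction of this step.

The step removes two chlorine atoms and brings in one bromine atom in a single move, so the compounds shown do not separate the loss of chlorine from the entry of bromine. A 4-chlorophenyl or an unsubstituted phenyl on the same oxygen would divide that step, while an amine or a carboxylic acid on that ring would show whether groups other than halogens also move the number.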